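The compounds below may be only part of what the source reports. "The series", "measured", "known", "first", "only" and "open" are said of these compounds alone.

Compound 2 `O=C1O[C@@H](CN2CCC(O)CC2)CN1c1ccc(-n2cc(-c3ccccn3)cn2)c(F)c1` gives 1.63 in a physicochemical assay for lipophilicity, read by HPLC, measured as octanol-water partition (on this read-out lower numbers stand for lower lipophilicity and higher numbers for higher lipophilicity), the lower of the two numbers recorded so far, while compound 1 `COC(=O)CC1CCN(C[C@H]2CN(c3ccc(-n4cc(-c5ccccn5)cn4)c(F)c3)C(=O)O2)CC1` gives 1.78 in this assay. Within the data shown here, the only step recorded, a number 0.15 log units lower from compound 1 to compound 2 (within the scatter), comes from a hydroxy in place of a (methoxycarbonyl)methyl group on a saturated ring carbon and lies within the scatter. Compound 3 `CC(=O)OC[C@H]1CN(c2ccc(-n3cc(-c4ccccn4)cn3)c(F)c2)C(=O)O1` differs from compound 2 by acetoxy in place of 4-hydroxypiperidin-1-yl on a saturated chain carbon bound to a saturated ring carbon. Among the measured compounds shown here, no measured step changes the same part of the molecule, so the one step known does not bear directly on this change, and an expectation can rest only on the structural difference itself. Compound 3 is expected to show a step of a number 0.67 log units higher from compound 2 to compound 3 (beyond the scatter) in this assay, toward higher lipophilicity. For compound 3 the estimated value in this assay is 2.3, with a range from 1.7 to 2.9.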

Compound 3, partition coefficient: 2.09
Compound 3: the middle estimate sits 0.21 log units above what was measured; the measured number falls inside the stated range.
By their numbers in this assay, from the lowest: compounds 2 and 1 (each within the scatter of the next); then compound 3.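

With compound 3 the change reaches the saturated chain carbon bound to a saturated ring carbon, and the 4-hydroxypiperidin-1-yl group gives way to acetoxy, which has no ring and no hydrogen-bond donor. In this assay, among these compounds, this replacement gives a number 0.46 log units higher from compound 2 to compound 3 (beyond the scatter) and is the first step from compound 2 to go beyond the scatter, while replacing 4-((methoxycarbonyl)methyl)piperidin-1-yl with acetoxy gives a number 0.31 log units higher from compound 1 to compound 3 (beyond the scatter) in the same direction. No evidence is at hand on the origin of these steps.

The compounds shown leave open whether these steps follow from the entry of acetoxy or from the departure of either piperidin-1-yl group, as each replacement does both at once. Also open, on these data alone, is how a simple amine such as dimethylamino, or a carboxylic acid, at this place would read in this assay.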